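Chain extension between ketone and hydroxypyrrolidine ring

The source may hold more compounds than are shown below. What is called first, only, known or untested is meant among the compounds shown, and "the series" means these compounds.

For the measured compounds named here, compound 1 `CCCCCCCCc1ccc(C(=O)C[C@@H]2C[C@@H](O)CN2)cc1` is the lower of the two measured members: in a functional assay on FL5.12 cells (Mus musculus), read by flow cytometry, with a stated time of 3 h, tested at 10 uM (a lower number here means a weaker effect, a higher number a stronger effect of the compound at the concentration tested), compound 1 gives 46%, while compound 2 `CCCCCCCCc1ccc(C(=O)C[C@H]2C[C@H](CO)CN2)cc1` gives 60%. Going by the values given here, the one measured step, a number 14 percentage points higher from compound 1 to compound 2 (beyond the scatter), exchanges the ring substituent and adds a carbon there. Compound 3 `CCCCCCCCc1ccc(C(=O)CC[C@@H]2C[C@@H](O)CN2)cc1` is not yet measured. Its change from compound 1 is (4-hydroxypyrrolidin-2-yl)methyl in place of 4-hydroxypyrrolidin-2-yl on a saturated chain carbon bound to a carbonyl carbon. This places the added carbon at a different spot, between the carbonyl side chain and the ring, so the measured step bears on it only loosely; both changes enlarge the polar head by a single carbon without altering its donor and acceptor count. A step of similar modest size in the same direction, or none beyond the scatter, is expected in this assay. The expected step is a number 6 percentage points higher from compound 1 to compound 3 (within the scatter). Compound 3 is therefore estimated at 52%, with a range from 32% to 72%.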

Compound 3, a percentage reported as activity, at one concentration (the size of the read-out at that concentration, not a potency): 52%
Beside the measured number, compound 3's estimate shows no gap at the digits printed, and the stated range covers the measured number.
By their numbers in this assay, from the lowest: compounds 1, 3 and 2 (each within the scatter of the next, the first and the last beyond it).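

In this assay the exchange of 4-hydroxypyrrolidin-2-yl for (4-hydroxypyrrolidin-2-yl)methyl on a saturated chain carbon bound to a carbonyl carbon gives a number 6 percentage points higher from compound 1 to compound 3 (within the scatter) and so adds a carbon here without a step that stands clear of the scatter. The comparison with the other enlarged group gives a number 8 percentage points lower from compound 2 to compound 3 (within the scatter) and does not separate these two groups of equal heavy-atom count, although only compound 2 stands beyond the scatter from compound 1. No available evidence explains these numbers.

Still open, from the compounds shown here alone, is whether a longer chain at this place would give a step beyond the scatter from compound 1. Also open, going by these compounds, is how an amine or a carboxylic acid would read in this assay in place of the hydroxyl group of compound 3.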